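From Amine to Amide on the Shared Core

A few compounds are considered here, and "the series" means these few. Any claim that something is new, unique, unknown or untested is made for them only; others in the source may bear on it.

Compound 1 `CCN(CC)C/C1=C/C[C@](C)(CCC=C(C)C)/C=C/[C@@H](OC(=O)C=C(C)C)[C@](C)(O)/C=C/C1=O` carries a (diethylamino)methyl group on a double-bonded ring carbon of its non-aromatic ring of carbon only. In a functional assay on MCF7 cells (Homo sapiens) for antiproliferative activity, read by MTT assay, with a stated time of 48 h (a lower number here means a stronger inhibitor, a higher number a weaker inhibitor), compound 1 gives 130 nM, the lowest number among the three compounds measured. Compound 2 `CC(C)=CCC[C@]1(C)/C=C/[C@@H](OC(=O)C=C(C)C)[C@](C)(O)/C=C/C(O)/C(C=O)=C\C1` gives 2320 nM in this assay, a gap from compound 1 beyond the scatter, and compound 3 `CC(C)=CCC[C@](C)(/C=C/[C@@H](OC(=O)C=C(C)C)[C@](C)(O)/C=C/C(=O)/C=C/N1CCN(C)CC1)CC=O` gives 8840 nM, the highest of the three. Compound 4 `CCN(CC)C(=O)/C1=C/C[C@](C)(CCC=C(C)C)/C=C/[C@@H](OC(=O)C=C(C)C)[C@](C)(O)/C=C/C1=O` differs from compound 1 in one place only: diethylcarbamoyl in place of (diethylamino)methyl on a double-bonded ring carbon. Going by the values given here, no measured pair that differs in a single place is at hand, so the size of this step rests on expectation alone. Neither compound 2, at 2320 nM, nor compound 3, at 8840 nM, carries the (diethylamino)methyl group, and both stand far above compound 1. Compound 4 is therefore expected to give a higher number than compound 1, a step of a 4.6-fold higher number from compound 1 to compound 4 (0.66 log units; beyond the scatter) in this assay, beyond the scatter. The estimate for compound 4 is 600 nM, between 120 nM and 3000 nM.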

Compound 4, half-maximal inhibitory concentration: 12100 nM
For compound 4 the middle estimate is 20-fold (1.30 log units) below the measured one; the measured number lies above the stated range.
By their numbers in this assay, from the lowest: compound 1; then compound 2; then compounds 3 and 4 (each within the scatter of the next).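

In this assay, diethylcarbamoyl in place of (diethylamino)methyl on the double-bonded ring carbon gives a 93-fold higher number from compound 1 to compound 4 (1.97 log units; beyond the scatter) and is the first change among these compounds that can be read at a single place. It shows that the number at this position depends strongly on the group's form, since both groups contain the same count of carbon and nitrogen atoms and the entering group adds a carbonyl oxygen. No data at hand account for the size of this step.

The compounds shown leave open whether the low number of compound 1 130 nM needs the diethylamino group itself or would persist with a dimethylaminomethyl, pyrrolidin-1-ylmethyl or morpholin-4-ylmethyl group at this place. They also leave open how a carboxylic acid or a hydroxymethyl group would read there.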